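A few compounds are considered here, and "the series" means these few. Any claim that something is new, unique, unknown or untested is made for them only; others in the source may bear on it.

Measured so far:
- compound 1 `C=CCOc1cc(OC)c(C(=O)/C=C/c2cccc(OC)c2)c(OCC=C)c1`: 142000 nM
- compound 2 `C=CCOc1cc(OC)c(C(=O)/C=C/c2ccccn2)c(OCC=C)c1`: 2800 nM
- compound 3 `C=CCOc1cc(OC)c(C(=O)/C=C/c2ccc(C)cc2)c(OCC=C)c1`: 211000 nM

In an ADME assay on Vero cells (Chlorocebus sabaeus) for cytotoxicity, read by MTT assay (on this read-out lower numbers stand for stronger inhibition and higher numbers for weaker inhibition), the values fall into two groups: there is a 1.5-fold higher number from compound 1 to compound 3 (0.17 log units; within the scatter), but also a 51-fold lower number from compound 1 to compound 2 (1.71 log units; beyond the scatter). Next is compound 4 `C=CCOc1cc(OC)c(C(=O)/C=C/c2ccc(OC)cc2)c(OCC=C)c1`, with the change (4-methoxyphenyl in place of 3-methoxyphenyl on a double-bonded chain carbon bound to a double-bonded chain carbon). The ring stays a six-membered aromatic ring of carbon only, as in compound 3, and the nearest evidence is a 1.5-fold higher number from compound 1 to compound 3 (0.17 log units; within the scatter). The large 75-fold higher number from compound 2 to compound 3 (1.88 log units; beyond the scatter) involves pyridin-2-yl, which does not occur in compound 4, so it bears less directly. Expected is a 1.1-fold higher number from compound 1 to compound 4 (0.02 log units; within the scatter), so no move beyond the scatter is anticipated. For compound 4 the estimated value is 150000 nM, with an expected range of 65000 nM to 300000 nM.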

Compound 4, half-maximal inhibitory concentration: 99900 nM
Beside the measured number, compound 4's estimate is 1.5-fold (0.18 log units) above it; low and high end bracket the measured number.
By their numbers in this assay, from the lowest: compound 2; then compounds 4, 1 and 3 (each within the scatter of the next, the first and the last beyond it).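

In this assay, 4-methoxyphenyl in place of 3-methoxyphenyl on a double-bonded chain carbon gives a 1.4-fold lower number from compound 1 to compound 4 (0.15 log units; within the scatter) and so does not separate the two methoxyphenyl compounds. Methoxy in place of methyl on an aromatic carbon gives a modest step, a 2.1-fold lower number from compound 3 to compound 4 (0.32 log units; beyond the scatter), while a 36-fold higher number from compound 2 to compound 4 (1.55 log units; beyond the scatter) leaves compound 2 well apart from all three compounds with a carbon-only ring. No measured evidence accounts for these steps.

Open, as far as these compounds go, is whether pyridin-3-yl or pyridin-4-yl at this place would stay close to compound 2 or to compounds 1, 3 and 4.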